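The source may report more compounds than this note shows. Statements on the series, on what has been measured and on what is new or still open speak of the compounds shown alone.

Measured so far in an ADME assay on HCT-116 cells (Homo sapiens) for cytotoxicity, read by MTT assay, with a stated time of 72 h; a higher number here means a weaker inhibitor, a lower number a stronger inhibitor:
compound 1 `CCCCCN1C(=O)C/C(=C\c2cccc(C(=O)Nc3cccc(CC)c3)c2)C1=O` gives 75300 nM
compound 2 `CCc1cccc(NC(=O)c2cccc(/C=C3\CC(=O)N(c4ccc(C)cc4)C3=O)c2)c1` gives 41500 nM

Going by the values given here, of the two numbers, the one for compound 1 is the larger, but the one step between them, a 1.8-fold lower number from compound 1 to compound 2 (0.26 log units; within the scatter), is within the scatter, so no order between compound 1 and compound 2 can be read from these data. That step swaps the group on the amide-type nitrogen in the ring; the anilide end is the same in both.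

Compound 3 `CCCCCN1C(=O)C/C(=C\c2cccc(C(=O)Nc3cccc(F)c3)c2)C1=O` differs from compound 1 at that anilide end: fluoro in place of ethyl on an aromatic carbon. Among the compounds with values here, no measured step touches this position, so nothing bears on it directly. Within the data shown here, the only step, a 1.8-fold lower number from compound 1 to compound 2 (0.26 log units; within the scatter), stayed within the scatter, and that is the sole guide. In this assay the change from compound 1 to compound 3 is therefore expected to give no step beyond the scatter, that is a 1.0-fold lower number from compound 1 to compound 3 (0.00 log units; within the scatter). For compound 3 the estimate is 75000 nM. The expected range for compound 3 runs from 30000 nM to 190000 nM; a limit rather than a number is possible given how weak the measured pair is.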

Compound 3, half-maximal inhibitory concentration: > 100000 nM
Compound 3: only a limit was reported; the forecaster's own chance of this, stated with the estimate: 15%; at least 1.3-fold (0.12 log units) between middle value and limit.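

Going by these compounds alone, this is the first measured change at the anilide end of the series: with fluoro in place of ethyl on an aromatic carbon, this assay gives an at least 1.3-fold higher number from compound 1 to compound 3 (0.12 log units; that floor lies within the scatter). Compound 3 gives > 100000 nM, which is a limit of the assay and not a number, so this step has only a floor, and that floor does not by itself separate the two compounds. The change from 3-ethylphenyl to 3-fluorophenyl therefore brings no sign of a stronger inhibitor at this position, and the series stays at the weak end of what the assay reports: the limit of > 100000 nM in this assay, at which 1 of the 3 values shown sits.

Whether any group at this position can give a clearly lower number remains open, since only ethyl and fluoro are shown there, and an amine, a carboxylic acid or a longer chain in that place would test it. Also open, going by these compounds, is whether fluoro at the anilide end reads the same with the 4-methylphenyl group of compound 2 on the ring nitrogen in place of pentyl.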